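The source may report more compounds than this note shows. Statements on the series, on what has been measured and on what is new or still open speak of the compounds shown alone.

Working notes on the series. Compound 1 `CN(C[C@H]1Cc2c(cccc2N2CCN(C3CC3)CC2)CN1)[C@H]1CCCc2cccnc21`, compound 2 `C[C@@H]1CN(c2cccc3c2C[C@H](CN(C)[C@H]2CCCc4cccnc42)NC3)C[C@H](C)N1` and compound 3 `CN1CCN(c2cccc3c2C[C@H](CN(C)[C@H]2CCCc4cccnc42)N(C)C3)CC1` share one core and differ only at the periphery; compound 4 `CN1CCN(c2cccc3c2C[C@H](CN(C)[C@H]2CCCc4cccnc42)NC3)CC1` belongs to the same set and is not yet measured. In a functional assay on CCRF-CEM cells for agonist activity at C-X-C chemokine receptor type 4 (Homo sapiens), read by calcium flux, with a stated time of 25 min (a higher number here means that more compound is needed for the effect, a lower number that less compound is needed), compound 1 gives only the assay limit, > 30000 nM. Compound 2 gives only the limit as well, > 30000 nM. Compound 3 likewise gives only the limit, > 30000 nM. The change from compound 1 to compound 2, 3,5-dimethylpiperazin-1-yl in place of 4-cyclopropylpiperazin-1-yl on an aromatic carbon, is therefore a step that the two limits leave unreadable from compound 1 to compound 2. All measured values sit at one point: the limit of > 30000 nM in this assay, at which 3 of the 3 values shown sit. Compound 4 differs from compound 3 by hydrogen in place of methyl on an amine nitrogen in a ring. Among the measured compounds shown here, no measured step bears on this change, and no measured step has a readable size, so no direction in this assay can be read from the series. Compound 4 is expected to remain at the limit, with an expected step of a number no higher from compound 3 to compound 4 (the limit leaves the size open). Compound 4 is estimated at 30000 nM, within 10000 nM to 100000 nM.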

Compound 4, half-maximal effective concentration: > 30000 nM
Compound 4: no number, only a limit; the forecaster's own chance of this, stated with the estimate: 75%; the middle value lies on the limit itself.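

In this assay, among the compounds shown here, compound 4 gives > 30000 nM as a limit of the assay, so no step among compound 1, compound 2, compound 3 and compound 4 can be read: the limit of > 30000 nM in this assay, at which 4 of the 4 values shown sit. The compounds shown leave open the size and direction of every change, and whether any structure in this set reaches a measurable response.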